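The compounds below may be only part of what the source reports. "The series", "measured", "known", "first", "only" and "open" are said of these compounds alone.

Notes on the series, step from compound 3 to compound 4.

Among the compounds with values here, compound 3 `CCOc1ncc(-c2nc(C(F)(F)F)sc2N2CCN(C(=O)Cn3ccc4cnccc43)[C@H](C)C2)cn1` gives 23 nM in a functional assay on U2OS cells for antagonist activity at C-X-C chemokine receptor type 3 (Homo sapiens), read by beta-arrestin recruitment (on this read-out higher numbers stand for weaker inhibition and lower numbers for stronger inhibition), which puts it second highest of the three numbers so far: compound 1 `CCOc1ncc(-c2nc(C(F)(F)F)sc2N2CCN(C(=O)Cn3cnc4cccnc43)[C@H](C)C2)cn1` gives 20 nM in this assay, within the scatter of compound 3, while compound 2 `CCOc1ncc(-c2nc(C(F)(F)F)sc2N2CCN(C(=O)Cn3ccc4cccnc43)[C@H](C)C2)cn1` gives 47 nM in this assay, a step of a 2.0-fold lower number from compound 2 to compound 3 (0.31 log units; beyond the scatter) that lies beyond the scatter.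

Compound 4 `CCOc1ncc(-c2nc(C(F)(F)F)sc2N2CCN(C(=O)Cn3ncc4cccnc43)[C@H](C)C2)cn1` differs from compound 3 by a group of 9 heavy atoms (6 carbon, 3 nitrogen; one five-membered aromatic ring with 2 hetero atoms, one six-membered aromatic ring with 1 hetero atom) in place of a group of 9 heavy atoms (7 carbon, 2 nitrogen; one five-membered aromatic ring with 1 hetero atom, one six-membered aromatic ring with 1 hetero atom), on a saturated chain carbon bound to a carbonyl carbon. The step from compound 1 to compound 3 is the same kind of exchange in the opposite direction, with the two-hetero-atom five-membered ring of compound 1 replaced by a one-hetero-atom ring, and it gave only a 1.2-fold higher number from compound 1 to compound 3 (0.06 log units; within the scatter). The other exchange of this kind, from compound 1 to compound 2, gave a 2.4-fold higher number from compound 1 to compound 2 (0.37 log units; beyond the scatter), a modest weakening. On that basis compound 4 is expected to sit close to compound 3, with the step of a 1.0-fold lower number from compound 3 to compound 4 (0.02 log units; within the scatter) not beyond the scatter. The estimate for compound 4 in this assay is 22 nM, with a range of 9 nM to 55 nM.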

Compound 4, half-maximal inhibitory concentration: 55 nM
Estimate against measurement, compound 4: 2.5-fold (0.40 log units) below, and the stated range covers the measured number.
By their numbers in this assay, from the lowest: compounds 1 and 3 (each within the scatter of the next); then compounds 2 and 4 (each within the scatter of the next).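

In this assay, the group with a five-membered aromatic ring with 2 hetero atoms does not behave as one kind of exchange: the two such groups differ beyond the scatter (a 2.8-fold higher number from compound 1 to compound 4 (0.44 log units; beyond the scatter)), so the hetero atom count of that ring does not alone set the number. The exchange of compound 3's group is not silent either (a 2.4-fold higher number from compound 3 to compound 4 (0.38 log units; beyond the scatter)), while compound 4 reads level with a group of the other ring count (a 1.2-fold higher number from compound 2 to compound 4 (0.07 log units; within the scatter)), leaving the four groups in two pairs, compounds 1 and 3 and compounds 2 and 4, each pair mixing both ring counts. No measurement shown accounts for this split.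

Open, going by these compounds, is whether a longer chain at the saturated chain carbon bound to a carbonyl carbon, or an amine or a carboxylic acid on the group, would keep the lower pair's numbers.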